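The source may hold more compounds than are shown below. What is called first, only, known or untested is meant among the compounds shown, and "the series" means these compounds.

In an assay on THP-1 cells for displacement of a labelled ligand from C-C chemokine receptor type 1 (Homo sapiens) (on this read-out lower numbers stand for stronger inhibition and higher numbers for weaker inhibition), compound 1 `CC(C)[C@@H](NC(=O)CCc1ccc(F)cc1)C(=O)N1CCC(c2ccc(Cl)cc2)CC1` gives 70 nM, the lowest of the three numbers available. Compound 3 `CC[C@@H](NC(=O)CCc1ccccc1)C(=O)N1CCC(c2ccc(Cl)cc2)CC1` gives 85 nM, which lies within the scatter of compound 1, so no order between the two can be claimed. Compound 2 `CC(C)C(=O)NC(C(=O)N1CCC(c2ccc(Cl)cc2)CC1)C(C)C` gives 388 nM, a number beyond the scatter of compound 1. Compound 4 `CC(C)[C@@H](NC(=O)CC1CC1)C(=O)N1CCC(c2ccc(Cl)cc2)CC1` has not yet been measured in this assay. It differs from compound 1 in one place: cyclopropyl in place of 4-fluorobenzyl on a saturated chain carbon bound to a carbonyl carbon. For the measured compounds named here, no measured pair shows this change on its own. Because compound 2, which likewise carries no aromatic ring on the chain bound to the carbonyl carbon, gives 388 nM, a step toward weaker inhibition beyond the scatter is expected, a 3.6-fold higher number from compound 1 to compound 4 (0.55 log units; beyond the scatter). Compound 4 is therefore estimated at 250 nM, within 100 nM to 700 nM.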

Compound 4, half-maximal inhibitory concentration: 46 nM
Estimate against measurement, compound 4: 5.4-fold (0.74 log units) above, outside the stated range (below it).
By their numbers in this assay, from the lowest: compounds 4, 1 and 3 (each within the scatter of the next); then compound 2.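

In this assay, replacing 4-fluorobenzyl with cyclopropyl on a saturated chain carbon bound to a carbonyl carbon gives a 1.5-fold lower number from compound 1 to compound 4 (0.18 log units; within the scatter). At this position, then, the six-membered aromatic ring is not required to keep the number in this range, and a group of 3 heavy atoms serves in place of one of 8. Nothing shown gives a reason for this result.

Going by these compounds, it remains open how an amine, a carboxylic acid or a longer alkyl chain would behave at this position. The same cyclopropyl exchange on compound 3 also remains to be read.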